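The source may hold more compounds than are shown below. What is called first, only, known or untested is meant among the compounds shown, and "the series" means these compounds.

Compound 1 `C=CC(=O)Nc1cc(Nc2ncc3ncn(-c4ccc(C(C)C)cc4)c3n2)c(OC)cc1N(C)CCN(C)C`: 15300 nM
Compound 2 `C=CC(=O)Nc1cc(Nc2ncc3ncn(-c4ccccc4F)c3n2)c(OC)cc1N(C)CCN(C)C`: 9750 nM

Both compounds share one core and differ only in the aryl group carried on the aromatic nitrogen of the fused ring system. In an ADME assay on HT-29 cells (Homo sapiens) for cytotoxicity, read by MTT assay, with a stated time of 72 h (a lower number here means a stronger inhibitor, a higher number a weaker inhibitor), compound 1 gives 15300 nM, while compound 2 gives 9750 nM. Among the compounds with values here, the single measured step, a 1.6-fold lower number from compound 1 to compound 2 (0.20 log units; within the scatter), is within the scatter, so compound 2 stands beside compound 1 with no separation that the assay can resolve; its only neighbour on these numbers is compound 1.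

Compound 3 `C=CC(=O)Nc1cc(Nc2ncc3ncn(-c4ccc(Cl)cc4Cl)c3n2)c(OC)cc1N(C)CCN(C)C` is not yet measured. It carries 2,4-dichlorophenyl in place of 2-fluorophenyl on an aromatic nitrogen.

Within the data shown here, the only measured step that bears on this change is a 1.6-fold lower number from compound 1 to compound 2 (0.20 log units; within the scatter), an exchange of one aryl group for another at the same aromatic nitrogen, and it stayed within the scatter. Among the measured compounds shown here, no other step is available. On that basis the step expected in this assay from compound 2 to compound 3 is a 1.1-fold higher number from compound 2 to compound 3 (0.05 log units; within the scatter), that is, none beyond the scatter. Compound 3 is therefore estimated at 11000 nM, with a range from 4000 nM to 30000 nM.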

Compound 3, half-maximal inhibitory concentration: 20600 nM
The estimate for compound 3 lay 1.9-fold (0.27 log units) below the measured number; the range from low to high includes it.
By their numbers in this assay, from the lowest: compounds 2, 1 and 3 (each within the scatter of the next, the first and the last beyond it).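

In this assay, within the data shown here, replacing 2-fluorophenyl with 2,4-dichlorophenyl on the aromatic nitrogen gives the only step at this position printed as beyond the scatter (a 2.1-fold higher number from compound 2 to compound 3 (0.32 log units; beyond the scatter)), a modest one, so the aryl group carried here can shift the number in this assay, if only slightly. The step to the same 2,4-dichlorophenyl group from 4-isopropylphenyl stays within the scatter (a 1.3-fold higher number from compound 1 to compound 3 (0.13 log units; within the scatter)), so these two aryl groups are not separated, and the single resolved difference among the three compounds lies between the 2-fluorophenyl and 2,4-dichlorophenyl groups. No measurement is available to explain this difference.

The change from compound 2 to compound 3 replaces fluorine with chlorine and also adds a second chlorine, and the compounds shown cannot assign the step to either part of that change. They also leave open how this assay would respond to a phenyl group carrying an amine or a carboxylic acid on this nitrogen, or to a longer alkyl chain in place of the aryl group.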